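Exchanging the aryl group on the shared core

A few compounds are considered here, and "the series" means these few. Any claim that something is new, unique, unknown or untested is made for them only; others in the source may bear on it.

In a functional assay on MCF-A cells (Homo sapiens) for cytotoxicity (a higher number here means a weaker inhibitor of growth, a lower number a stronger inhibitor of growth), compound 3 `CSc1ccc(C2=C(c3ccc(C)c(C)c3)C(=O)N3CCCC3C2)cc1` gives 800 nM. Compound 2 `CSc1ccc(C2=C(c3ccc(F)c(F)c3)C(=O)N3CCCC3C2)cc1` stands level with it at 800 nM, and together they hold the lowest of the three numbers, while compound 1 `COc1ccc(C2=C(c3ccc(SC)cc3)CC3CCCN3C2=O)cc1OC(=O)CNC(=O)OC(C)(C)C` gives 6000 nM. Compound 4 `COc1ccc(C2=C(c3ccc(SC)cc3)CC3CCCN3C2=O)cc1` differs from compound 3 on a double-bonded ring carbon: 4-methoxyphenyl in place of 3,4-dimethylphenyl on a double-bonded ring carbon. For the measured compounds named here, one measured step bears on this place, no change at the digits printed from compound 2 to compound 3 (within the scatter), an exchange of 3,4-difluorophenyl for 3,4-dimethylphenyl that stayed within the scatter. Going by the values given here, no measured step introduces 4-methoxyphenyl alone, so this evidence is thin. No step beyond the scatter is therefore expected, and the estimated change is a 1.3-fold lower number from compound 3 to compound 4 (0.12 log units; within the scatter). Compound 4 is expected at about 600 nM, with an estimated range of 200 nM to 1800 nM.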

Compound 4, concentration for 50% growth inhibition: 5000 nM
Compound 4: the middle estimate sits 8.3-fold (0.92 log units) below what was measured; the measured number lies above the stated range.
By their numbers in this assay, from the lowest: compounds 2 and 3 (each within the scatter of the next); then compounds 4 and 1 (each within the scatter of the next).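

In this assay, this carbon proved sensitive to the aryl group, although 3,4-dimethylphenyl and 3,4-difluorophenyl had stood level: 4-methoxyphenyl in place of the former gave a 6.3-fold higher number from compound 3 to compound 4 (0.80 log units; beyond the scatter), and in place of the latter gave a 6.3-fold higher number from compound 2 to compound 4 (0.80 log units; beyond the scatter). A hydrogen atom in place of the group of 12 heavy atoms, on an aromatic carbon, gave a 1.2-fold lower number from compound 1 to compound 4 (0.08 log units; within the scatter). Nothing at hand accounts for the gap between these aryl groups. Going by these compounds, it remains open how 4-methylphenyl, 3,4-dimethoxyphenyl or 4-aminophenyl would read at this carbon.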